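The source may report more compounds than this note shows. Statements on the series, on what has been measured and on what is new or still open speak of the compounds shown alone.

Measured so far in an ADME assay on blood (Homo sapiens) for pharmacokinetics; on this read-out lower numbers stand for a shorter-lived compound and higher numbers for a longer-lived compound:
- compound 1 `COC(=O)CCNC(=O)[C@@H]1O[P@@](=O)(OCOC(=O)c2ccns2)OCC1(C)C` gives < 0.16 h, which is a limit of this assay and not a number.
- compound 2 `COC(=O)CCNC(=O)[C@@H]1O[P@](=O)(Oc2ccc(C(F)(F)F)cc2)OCC1(C)C` gives > 1 h, again a limit of this assay rather than a number.
- compound 3 `COC(=O)CCNC(=O)[C@@H]1O[P@](=O)(Oc2ccc(C#N)cc2)OCC1(C)C` gives 0.46 h.

Within the data shown here, compound 3 therefore stands as the only compound of the three with a measured number in this assay; the other two sit at limits the limit of < 0.16 h in this assay, at which 1 of the 3 values shown sits (the limit of > 1 h in this assay, at which 1 of the 3 values shown sits). Among the measured compounds shown here, the one step between measured compounds is an at least 2.1-fold lower number from compound 2 to compound 3 (0.33 log units; beyond the scatter), a cyano in place of trifluoromethyl on an aromatic carbon, which shortened the half-life by a modest amount.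

Compound 4 `COC(=O)CCNC(=O)[C@@H]1O[P@](=O)(OCOC(=O)c2ccns2)OCC1(C)C` differs from compound 3 in one place: (((1,2-thiazol-5-yl)carbonyl)oxy)methyl in place of 4-cyanophenyl on an oxygen. For the measured compounds named here, this is a different kind of change from the single measured step, which only swapped one small substituent on the ring, so that step gives little guidance. More telling is compound 1, which carries the same (((1,2-thiazol-5-yl)carbonyl)oxy)methyl group and gives < 0.16 h, a limit of this assay. On that basis compound 4 is expected to be short-lived, with an estimated step of a 3.8-fold lower number from compound 3 to compound 4 (0.58 log units; beyond the scatter), and an estimated half-life of 0.12 h (range 0.05 h to 0.3 h).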

Compound 4, half-life: < 0.16 h
Compound 4 ended at the assay's limit; the forecaster's own chance of this, stated with the estimate: 70%; the middle value lies beyond the limit too.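

Moving to the (((1,2-thiazol-5-yl)carbonyl)oxy)methyl group in place of 4-cyanophenyl, on the oxygen bonded to phosphorus, gives an at least 2.8-fold lower number from compound 3 to compound 4 (0.45 log units; beyond the scatter) in this assay, the first readable measure of this change at this position. Compound 4 gives a limit of the assay and not a number, and it shares that limit with compound 1: the limit of < 0.16 h in this assay, at which 2 of the 4 values shown sit. The step between compound 1 and compound 4 cannot be read, so the configuration at phosphorus shows no readable effect here: the fact that compounds 1 and 4 differ only in the configuration as drawn.

Still open, as far as these compounds go, is how short-lived compound 1 and compound 4 really are, and whether the configuration at phosphorus matters for this group at all. Also open, from the compounds shown here alone, is where a plain phenyl or a (pivaloyloxy)methyl group on the same oxygen would fall.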